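Adding a large group to the nitrogen of compound 2

A few compounds are considered here, and "the series" means these few. Any claim that something is new, unique, unknown or untested is made for them only; others in the source may bear on it.

Three related compounds have been measured in a functional assay on K562 cells (Homo sapiens) for cytotoxicity, read by trypan blue exclusion, with a stated time of 96 h; on this read-out lower numbers stand for stronger inhibition and higher numbers for weaker inhibition. Compound 2 `COc1cc(OC)c(/C=C/S(=O)(=O)Nc2ccc(OC)c(N)c2)c(OC)c1` gives 3 nM, the lowest of the three numbers. Compound 1 `COc1cc(OC)c(/C=C/S(=O)(=O)Nc2ccc(F)c(N)c2)c(OC)c1` gives 5000 nM, and compound 3 `COc1ccc(NS(=O)(=O)/C=C/c2c(OC)cc(OCCCC(=O)O)cc2OC)cc1N` gives 10000 nM. Methoxy in place of fluoro on an aromatic carbon goes with a 1700-fold lower number from compound 1 to compound 2 (3.22 log units; beyond the scatter). Among these three compounds, then, one small edit can move the number a long way.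

Compound 4 `COC(=O)C(Nc1cc(NS(=O)(=O)/C=C/c2c(OC)cc(OC)cc2OC)ccc1OC)c1ccc(Br)cc1` has (4-bromophenyl)(methoxycarbonyl)methyl in place of hydrogen on a nitrogen on an aromatic ring. Within the data shown here, no measured compound carries a change at that nitrogen, so the evidence is indirect. The nearest guide is compound 3, where 2-carboxyethyl in place of hydrogen on a saturated chain carbon bound to an oxygen on an aromatic ring goes with a 3300-fold higher number from compound 2 to compound 3 (3.52 log units; beyond the scatter). That was an addition to compound 2 at a different place and with a different group, so a rise is expected here too, though a smaller one and with much uncertainty. The expected step is a 33-fold higher number from compound 2 to compound 4 (1.52 log units; beyond the scatter), towards weaker inhibition. Compound 4 is estimated at 100 nM, with an expected range of 5 nM to 3000 nM.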

Compound 4, half-maximal inhibitory concentration: 1000 nM
For compound 4 the middle estimate is 10-fold (1.00 log units) below the measured one; low and high end bracket the measured number.
By their numbers in this assay, from the lowest: compound 2; then compound 4; then compounds 1 and 3 (each within the scatter of the next).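

Among these compounds, the nitrogen on the aromatic ring carries hydrogen in compounds 1 to 3, so this is the first direct reading at that position: in this assay, (4-bromophenyl)(methoxycarbonyl)methyl in place of hydrogen goes with a 330-fold higher number from compound 2 to compound 4 (2.52 log units; beyond the scatter). This makes the nitrogen a second place on compound 2 where adding a group goes with a large rise, alongside the saturated chain carbon bound to an oxygen, where the change goes with a 3300-fold higher number from compound 2 to compound 3 (3.52 log units; beyond the scatter). The data give no measurement that explains the rise at the nitrogen.

On these data alone, what stays open is which part of the entering group, with its 12 heavy atoms, goes with the step: the bromine, the six-membered aromatic ring or the methoxycarbonyl. The compounds shown also leave unanswered how the number would respond to a small group such as methyl on the same nitrogen, or to a carboxylic acid in place of the methyl ester.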